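Aryl variation on the ethenyl chain, working notes

The source may hold more compounds than are shown below. What is called first, only, known or untested is meant among the compounds shown, and "the series" means these compounds.

Compound 1 `COc1cc2nc(/C=C/c3cccnc3)nc(N3CCC(CCNS(N)(=O)=O)CC3)c2cc1OC`: 86%
Compound 2 `COc1cc2nc(/C=C/c3ccncc3)nc(N3CCC(CCNS(N)(=O)=O)CC3)c2cc1OC`: 79%
Compound 3 `COc1cc2nc(/C=C/c3ccc(F)cc3)nc(N3CCC(CCNS(N)(=O)=O)CC3)c2cc1OC`: 70%

All three were measured in an assay on cells for inhibition of Ectonucleotide pyrophosphatase/phosphodiesterase family member 1 (Homo sapiens), with a stated time of 60 min, tested at 1 uM; on this read-out higher numbers stand for more inhibition at the one concentration tested (going by the name of the read-out) and lower numbers for less inhibition. Compound 3 gives the lowest of the three numbers; its nearest neighbour is compound 2, and the gap a number 9 percentage points lower from compound 2 to compound 3 (within the scatter) lies within the scatter, while a number 16 percentage points lower from compound 1 to compound 3 (beyond the scatter) lies beyond it. Compound 4 `COc1cccc(/C=C/c2nc(N3CCC(CCNS(N)(=O)=O)CC3)c3cc(OC)c(OC)cc3n2)c1` differs from compound 3 in one place: 3-methoxyphenyl in place of 4-fluorophenyl on a double-bonded chain carbon bound to a double-bonded chain carbon. Within the data shown here, no measured step replaces one carbon-only ring by another; the steps of a number 16 percentage points lower from compound 1 to compound 3 (beyond the scatter) and a number 9 percentage points lower from compound 2 to compound 3 (within the scatter) only set pyridin-3-yl and pyridin-4-yl against 4-fluorophenyl. They give no direction for compound 4, so no step beyond the scatter is expected: no change at the digits printed from compound 3 to compound 4 (within the scatter). Compound 4 is therefore estimated at 70%, between 55% and 83%.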

Compound 4, a percentage reported as inhibition, at one concentration (the size of the read-out at that concentration, not a potency): 88%
Compound 4: the middle estimate sits 18 percentage points below what was measured, outside the stated range (above it).
By their numbers in this assay, from the lowest: compounds 3, 2, 1 and 4 (each within the scatter of the next, the first and the last beyond it).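

Among carbon-only rings on this chain carbon, the choice of ring substituent counts: 3-methoxyphenyl in place of 4-fluorophenyl gives a number 18 percentage points higher from compound 3 to compound 4 (beyond the scatter) in this assay and so a carbon-only ring need not read low against the pyridines. Against those pyridines the readings are a number 9 percentage points higher from compound 2 to compound 4 (within the scatter) and a number 2 percentage points higher from compound 1 to compound 4 (within the scatter) and set no order among the three. Nothing measured on these compounds accounts for the step.

Open, as far as these compounds go, is whether the methoxy group itself or its place on the ring carries the step; 3-fluorophenyl and 4-methoxyphenyl on the same chain carbon would separate the two. Also open, from the compounds shown here alone, is how a ring bearing an amine or a carboxylic acid would read here.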